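Cytotoxicity notes: aryl variation on the shared core

The source may report more compounds than this note shows. Statements on the series, on what has been measured and on what is new or still open speak of the compounds shown alone.

Measured so far:
compound 1 `CCOC(=O)CCCCCOc1cccc(CN(C(=O)c2ccc(-c3ccco3)cc2)C(C)C)c1` — > 26000 nM
compound 2 `CCOC(=O)CCCCCOc1cccc(CN(C(=O)c2ccc(-c3ccc4cc[nH]c4c3)cc2)C(C)C)c1` — > 26000 nM

In an ADME assay on Raji cells (Homo sapiens) for cytotoxicity, read by CellTiter-Glo and resazurin assay, with a stated time of 72 h (on this read-out higher numbers stand for an effect only at larger amounts of compound and lower numbers for an effect already at smaller amounts), compound 1 gives > 26000 nM, which is a limit of the assay and not a number. In this assay compound 2 gives > 26000 nM, likewise a limit. Compound 2 therefore stands at the limit, as does compound 1, and the step that the two limits leave unreadable from compound 1 to compound 2 cannot be read in either direction.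

Compound 3 (`CCOC(=O)CCCCCOc1cccc(CN(C(=O)c2ccc(-c3cccc(OC(F)(F)F)c3)cc2)C(C)C)c1`) is not yet measured. It differs from compound 2 by 3-(trifluoromethoxy)phenyl in place of 1H-indol-6-yl on an aromatic carbon. Among the compounds with values here, the only measured step touching this position is a step that the two limits leave unreadable from compound 1 to compound 2, and the two limits leave its size unreadable, so the data give no size of effect for a change at this position. Within the data shown here, because of the limit of > 26000 nM in this assay, at which 2 of the 2 values shown sit, the series so far shows no numeric value at all in this assay, and a third compound with a changed aryl group at the same place has no measured step to suggest a departure from that picture.

Compound 3 is accordingly expected to give 40000 nM in this assay, with a range of 15000 nM to 120000 nM, most likely reported again only as a limit. Among the measured compounds shown here, the expected step that the limit leaves unreadable from compound 2 to compound 3 is an estimate with no measured step behind it.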

Compound 3, half-maximal effective concentration: > 26000 nM
Compound 3 was reported as a limit; the forecaster's own chance of this, stated with the estimate: 85%; the middle value lies beyond the limit too.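

No step can be read among compound 1, compound 2 and compound 3 in this assay, since all three values are limits of the assay and not numbers: the limit of > 26000 nM in this assay, at which 3 of the 3 values shown sit.

The compounds shown leave open whether any aryl group at this place on the shared core gives a numeric value in this assay and how large a step there could be.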